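The source may hold more compounds than are shown below. What is called first, only, known or untested is meant among the compounds shown, and "the series" means these compounds.

Measured so far in a functional assay on MDA-MB-231 cells (Homo sapiens) for antiproliferative activity, read by MTT assay, with a stated time of 72 h; on this read-out lower numbers stand for stronger inhibition and higher numbers for weaker inhibition:
compound 1 `CCCn1ccnc1-c1cc(OC)c(OC)c(OC)c1`: > 100000 nM
compound 2 `COc1cc(-c2nccn2-c2ccc3cc[nH]c3c2)cc(OC)c1OC`: 7500 nM

In this assay compound 1 gives only a limit and no number, > 100000 nM. This stands as the limit of > 100000 nM in this assay, at which 1 of the 2 values shown sits. For compound 2 this assay does give a number, 7500 nM. Compound 3 `COc1cc(-c2nccn2-c2ccc(F)cc2)cc(OC)c1OC` has not yet been measured in this assay. It differs from compound 1 in one place: 4-fluorophenyl in place of propyl on an aromatic nitrogen. Going by the values given here, no two measured compounds differ in a single place, so no measured step sets the size of this change directly. Compound 2, which likewise bears an aromatic group on the ring nitrogen of the shared core, lands well inside the range of this assay, whereas compound 1 does not; on that basis a gain in potency beyond the scatter is expected for the step from compound 1 to compound 3, though a limit read-out for compound 3 cannot be excluded. For compound 3 the estimate in this assay is 12000 nM, with a range from 3000 nM to 60000 nM. This amounts to an expected step of an at least 8.3-fold lower number from compound 1 to compound 3 (0.92 log units; beyond the scatter).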

Compound 3, half-maximal inhibitory concentration: 38400 nM
Beside the measured number, compound 3's estimate is 3.2-fold (0.51 log units) below it; the range from low to high includes it.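

In this assay, going by these compounds alone, 4-fluorophenyl in place of propyl on the aromatic nitrogen gives an at least 2.6-fold lower number from compound 1 to compound 3 (0.41 log units; beyond the scatter), the first step at this position that can be read between two compounds differing in one place. Compound 1 gives only a limit and not a number, so this step is a minimum and its full size stays unknown: the limit of > 100000 nM in this assay, at which 1 of the 3 values shown sits.

An aromatic ring on this nitrogen now brings a measurable number in two compounds, with compound 2 at 7500 nM and compound 3 at 38400 nM, so the printed values put compound 3 higher than compound 2 and show that the choice of aromatic group matters here.

Whether the gain over propyl comes from the six-membered aromatic ring itself or from its fluorine remains open, since neither an unsubstituted phenyl nor a 4-chlorophenyl is among the compounds shown. Also open, as far as these compounds go, is how a benzyl group, a longer chain or a chain ending in an amine on the same nitrogen would read, and thus whether the aromatic ring is needed at all.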